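Nitro to bromo on the aryl of the shared core

This account rests on a few compounds, and the source may have more. Where it says the series, first, only, none or still open, it means among the compounds named here.

Measured compounds:
compound 1 `COc1ccc(C2CC(c3ccc(OCc4cn(Cc5ccc([N+](=O)[O-])cc5)nn4)cc3)=NN2C(C)=O)cc1` — 26%
compound 2 `COc1cc(C2CC(c3ccc([N+](=O)[O-])cc3)=NN2C(C)=O)ccc1OCc1cn(Cc2ccc([N+](=O)[O-])cc2)nn1` — 59%

In a functional assay on THP-1 cells (Homo sapiens) for inhibition, read by sulforhodamine B assay, tested at 100 uM (on this read-out higher numbers stand for more inhibition of growth at the one concentration tested and lower numbers for less inhibition of growth), compound 2 gives 59% and stands highest of the two numbers; compound 1 gives 26%, a gap beyond the usual scatter. Compound 3 `COc1cc(C2CC(c3ccc(Br)cc3)=NN2C(C)=O)ccc1OCc1cn(Cc2ccc([N+](=O)[O-])cc2)nn1` differs from compound 2 by bromo in place of nitro on an aromatic carbon. Among the compounds with values here, no measured pair shows this change, so its effect is unknown; the expected step from compound 2 to compound 3 in this assay is a number 14 percentage points lower from compound 2 to compound 3 (beyond the scatter), a modest loss that may not exceed the scatter. Compound 3 is estimated at 45%, within 25% to 65%.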

Compound 3, percent growth inhibition at one concentration: 23%
Compound 3: middle estimate off by 22 percentage points, on the high side; the measured number lies below the stated range.
By their numbers in this assay, from the lowest: compounds 3 and 1 (each within the scatter of the next); then compound 2.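

The first step readable in the series falls on the aromatic carbon para to a large group: in this assay, 4-nitrophenyl to 4-bromophenyl gives a number 36 percentage points lower from compound 2 to compound 3 (beyond the scatter). The position is therefore not indifferent to its substituent, and bromo does not stand in for nitro here. Nothing at hand gives a reason for this loss.

From the compounds shown here alone, whether an amine or a carboxylic acid on this carbon would keep the number of compound 2 stays open. So does whether the same swap would matter on the nitro-bearing benzyl group at the triazole.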